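A few compounds are considered here, and "the series" means these few. Any claim that something is new, unique, unknown or untested is made for them only; others in the source may bear on it.

Measured compounds in an in vitro ADME assay on microsomes (Mus musculus) for metabolic stability; a lower number here means that the compound disappears faster, a higher number that the compound lasts longer:
Compound 1 `CNC(=O)Nc1ccc(-c2nc(N3CC4CCC(C3)O4)c3cnn([C@H]4CC[C@@H](OC)CC4)c3n2)cc1` gives 0.283 h.
Compound 2 `O=C(Nc1ccc(-c2nc(N3CC4CCC(C3)O4)c3cnn(C4CCC5(CC4)OCCO5)c3n2)cc1)Nc1cccnc1` gives only a limit, > 0.5 h.
Compound 3 `CNC(=O)Nc1ccc(-c2nc(N3CC4CCC(C3)O4)c3cnn([C@H]4CC[C@H](O)CC4)c3n2)cc1` gives only a limit, > 0.5 h.

Going by the values given here, compound 1 thus holds the only plain number among the three; the other two sit at the limit of > 0.5 h in this assay, at which 2 of the 3 values shown sit. Compound 4 `CNC(=O)Nc1ccc(-c2nc(N3CC4CCC(C3)O4)c3cnn(C4CCC(OC)(OC)CC4)c3n2)cc1` has not been measured; it differs from compound 1 by a group of 10 heavy atoms (8 carbon, 2 oxygen; one six-membered non-aromatic ring of carbon only) in place of a group of 8 heavy atoms (7 carbon, 1 oxygen; one six-membered non-aromatic ring of carbon only), on an aromatic nitrogen. Among the compounds with values here, the one step measured on this ring, an at least 1.7-fold higher number from compound 1 to compound 3 (0.24 log units; that floor lies within the scatter), exchanged one group for another on the same position and did not rise beyond the scatter with certainty. Compound 4 instead keeps a methoxy and adds a second one, so that step bears only loosely on it, and no direction beyond the scatter is expected. Compound 4 is therefore estimated at 0.3 h, ranging from 0.15 h to 0.6 h, which is expected to be a 1.1-fold higher number from compound 1 to compound 4 (0.03 log units; within the scatter).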

Compound 4, half-life: 0.25 h
Compound 4: the middle estimate sits 1.2-fold (0.08 log units) above what was measured; low and high end bracket the measured number.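

In this assay, the larger group of compound 4 in place of 4-methoxycyclohexyl on the aromatic nitrogen gives a 1.1-fold lower number from compound 1 to compound 4 (0.05 log units; within the scatter), so the two compounds cannot be told apart. Against 4-hydroxycyclohexyl, the same group gives an at least 2.0-fold lower number from compound 3 to compound 4 (0.30 log units; that floor lies within the scatter), and only a floor can be read for this step: the limit of > 0.5 h in this assay, at which 2 of the 4 values shown sit.

The compounds shown leave open how far compound 3 truly lies from compound 1 and compound 4. They also leave open whether an amine or a carboxylic acid on this cyclohexyl ring would move the half-life beyond the scatter.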